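This account rests on a few compounds, and the source may have more. Where it says the series, first, only, none or still open, it means among the compounds named here.

In a functional assay on SK-BR-3 cells (Homo sapiens) for inhibition, read by CCK-8 assay, with a stated time of 72 h, tested at 20 uM (on this read-out higher numbers stand for more inhibition of growth at the one concentration tested and lower numbers for less inhibition of growth), three compounds have been measured:

compound 1 `CC(C)(C)OC(=O)/C=C1/C(=O)Nc2ccccc21` — 87.3%
compound 2 `Cc1ccc2c(c1)/C(=C\C(=O)OC(C)(C)C)C(=O)N2` — 88%
compound 3 `CC(C)c1ccc2c(c1)/C(=C\C(=O)OC(C)(C)C)C(=O)N2` — 88.5%

All three numbers sit close together. Compound 1 stands with the other two rather than apart from them: a number 0.7 percentage points higher from compound 1 to compound 2 (within the scatter) and a number 1.2 percentage points higher from compound 1 to compound 3 (within the scatter), and between the two substituted compounds a number 0.5 percentage points higher from compound 2 to compound 3 (within the scatter). None of these changes moved the read-out in this assay beyond the scatter.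

Compound 4 `CC(C)(C)OC(=O)/C=C1/C(=O)Nc2ccc([N+](=O)[O-])cc21` has not yet been measured. It differs from compound 1 in one place: nitro in place of hydrogen on an aromatic carbon. Among the compounds with values here, the steps that bear on this are those from compound 1 to compound 2 and from compound 1 to compound 3, each of which also replaced a hydrogen on an aromatic carbon of the shared core and each of which left the number essentially where it was. Within the data shown here, no measured step shows what a nitro group, as opposed to an alkyl group, does at this position, so the expectation rests only on the flatness seen so far. Compound 4 is therefore expected to give 86% in this assay, within a range of 72% to 93%. The expected step is a number 1.3 percentage points lower from compound 1 to compound 4 (within the scatter), that is, nothing beyond the scatter.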

Compound 4, percent growth inhibition at one concentration: 87.9%
For compound 4 the middle estimate is 1.9 percentage points below the measured one, and the stated range covers the measured number.
By their numbers in this assay, from the lowest: compounds 1, 4, 2 and 3 (each within the scatter of the next).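

In this assay, nitro in place of hydrogen on an aromatic carbon gives (a number 0.6 percentage points higher from compound 1 to compound 4 (within the scatter)), so the tolerance of this position now extends beyond the alkyl groups methyl and isopropyl to a group that brings in nitrogen and oxygen. The comparisons with the alkyl compounds agree: nitro in place of isopropyl gives (a number 0.6 percentage points lower from compound 3 to compound 4 (within the scatter)) and nitro in place of methyl gives (a number 0.1 percentage points lower from compound 2 to compound 4 (within the scatter)), so hydrogen, methyl, isopropyl and nitro at this position cannot be told apart on this read-out at the one concentration tested. No measurement shown here offers an explanation for this result.

What the compounds shown leave open is whether an amine, a carboxylic acid or a longer chain on this aromatic carbon would also leave the number in place, and whether any of the four compounds would separate from the others at lower concentrations. They also leave open how far the number depends on the parts of the shared core that stay the same throughout, such as the tert-butyl ester and the amide hydrogen.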